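The compounds below may be only part of what the source reports. "The series", "measured", "known", "first", "only" and "open" are said of these compounds alone.

Of the compounds shown here, two have been measured in an assay on isolated protein for binding affinity to sphingosine 1-phosphate receptor 2 (Homo sapiens), read by surface plasmon resonance; on this read-out higher numbers stand for weaker binding and lower numbers for tighter binding. Compound 1 `CC(C)c1cc(NNC(=O)Nc2cc(Cl)nc(Cl)c2)nc2c1c(C(F)(F)F)nn2C` gives 1250 nM in this assay. Compound 2 `Cc1nn(C)c2nc(NNC(=O)Nc3cc(Cl)nc(Cl)c3)cc(-c3ccco3)c12` gives 6520 nM in this assay, the higher of the two numbers, so it binds more weakly than compound 1. Compound 3 `Cc1nn(C)c2nc(NNC(=O)Nc3cc(Cl)nc(Cl)c3)cc(C3CCCCC3)c12` has not yet been measured; it differs from compound 2 in one place: cyclohexyl in place of furan-2-yl on an aromatic carbon. For the measured compounds named here, no measured pair shows what this exchange does, so the expected step from compound 2 to compound 3 in this assay is modest, towards tighter binding, estimated as a 2.2-fold lower number from compound 2 to compound 3 (0.34 log units; beyond the scatter). Compound 3 is therefore expected to give roughly 3000 nM, between 900 nM and 10000 nM.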

Compound 3, dissociation constant: 2010 nM
Estimate against measurement, compound 3: 1.5-fold (0.17 log units) above; low and high end bracket the measured number.
By their numbers in this assay, from the lowest: compounds 1 and 3 (each within the scatter of the next); then compound 2.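

Exchanging furan-2-yl for cyclohexyl on this aromatic carbon gives a 3.2-fold lower number from compound 2 to compound 3 (0.51 log units; beyond the scatter) in this assay, a modest move towards tighter binding. At this position, then, an aromatic ring with an oxygen is not needed for binding: a non-aromatic ring of carbon only, with no hydrogen-bond acceptor, does better. No available evidence explains the direction of this step. Still open, as far as these compounds go, is how a flat phenyl ring, a smaller cyclopentyl ring or a ring carrying an amine would compare here. From the compounds shown here alone, whether the same exchange has a similar effect on other cores also remains open.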